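Amine head group swap from compound 3 to compound 4

A few compounds are considered here, and "the series" means these few. Any claim that something is new, unique, unknown or untested is made for them only; others in the source may bear on it.

Three measured compounds share one core and differ only in the basic group on a saturated ring carbon. Compound 1 `COc1cc(C)c(S(=O)(=O)N(C)CCOCC(=O)N2CCC(C3CCN(C)CC3)CC2)c(C)c1` gives 9 in a functional assay on Umbilical vein for antagonist activity at B1 bradykinin receptor (Homo sapiens), using Schild analysis, with a stated time of 30 min; a lower number here means a less potent compound, a higher number a more potent compound, by a factor of ten per unit of this negative logarithm. Compound 2 `COc1cc(C)c(S(=O)(=O)N(C)CCOCC(=O)N2CCC(C(C)(C)CN(C)C)CC2)c(C)c1` gives 7.5 in this assay, the step being a number 1.50 log units lower from compound 1 to compound 2 (beyond the scatter). Compound 3 `COc1cc(C)c(S(=O)(=O)N(C)CCOCC(=O)N2CCC(C3CCN(C(C)C)CC3)CC2)c(C)c1` gives 9.3 in this assay and stands highest of the three numbers; compound 1 is nearest, since a number 0.30 log units higher from compound 1 to compound 3 (within the scatter), and compound 2 is furthest, since a number 1.80 log units higher from compound 2 to compound 3 (beyond the scatter).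

Compound 4 `COc1cc(C)c(S(=O)(=O)N(C)CCOCC(=O)N2CCC(CN3CCN(C)CC3)CC2)c(C)c1` is still to be measured. The change is (4-methylpiperazin-1-yl)methyl in place of 1-isopropylpiperidin-4-yl on a saturated ring carbon. Among the measured compounds shown here, two measured steps bear on it: the large loss a number 1.50 log units lower from compound 1 to compound 2 (beyond the scatter) and its large reverse a number 1.80 log units higher from compound 2 to compound 3 (beyond the scatter), both of which show that moving the amine nitrogen out of a ring onto a branched chain costs heavily, while a number 0.30 log units higher from compound 1 to compound 3 (within the scatter) shows that the substituent on the ring nitrogen changes little. For the measured compounds named here, compound 4 keeps a ring that carries the amine nitrogen but inserts a methylene between the two rings and adds a second ring nitrogen; no measured pair covers this exactly. A moderate loss, smaller than that from compound 1 to compound 2, is therefore expected, namely a number 1.00 log units lower from compound 3 to compound 4 (beyond the scatter). For compound 4 the estimate in this assay is 8.3, with a range from 7.5 to 9.1.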

Compound 4, negative logarithm of the antagonist equilibrium constant: 8.1
Estimate against measurement, compound 4: 0.20 log units above; measured number inside the range.
By their numbers in this assay, from the lowest: compound 2; then compound 4; then compounds 1 and 3 (each within the scatter of the next).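

In this assay, the (4-methylpiperazin-1-yl)methyl group shows that this saturated ring carbon does not simply divide its groups into those with and without a ring carrying the amine: the change to compound 4 is a number 1.20 log units lower from compound 3 to compound 4 (beyond the scatter) and a number 0.90 log units lower from compound 1 to compound 4 (beyond the scatter), yet also a number 0.60 log units higher from compound 2 to compound 4 (beyond the scatter). Among the groups shown, holding a six-membered non-aromatic ring is therefore not enough to keep the level of the two piperidinyl compounds, although compound 4 still stands clear of the open-chain 1-((dimethylamino)methyl)-1-methylethyl group of compound 2. No measurement at hand accounts for these differences.

The entering group differs from 1-isopropylpiperidin-4-yl in more than one feature, since it adds a methyl-linked attachment and a ring with 2 hetero atoms, so the compounds shown do not divide the loss between those features. From the compounds shown here alone, a (1-methylpiperidin-4-yl)methyl group or a 4-methylpiperazin-1-yl group on the same ring carbon would each alter only one of them, and how either would read in this assay remains open.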